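This account rests on a few compounds, and the source may have more. Where it says the series, first, only, none or still open, it means among the compounds named here.

Of the compounds shown here, two have been tested in a functional assay on A549 cells (Homo sapiens) for antiproliferative activity, read by MTT assay, with a stated time of 72 h; on this read-out higher numbers stand for weaker inhibition and lower numbers for stronger inhibition. Compound 1 `O=C(Nc1ccc(Oc2ccnc3[nH]ccc23)cc1)c1cc2cccnc2n(-c2ccc(Br)cc2F)c1=O` gives 1570 nM, and compound 2 `COc1ccc(-n2c(=O)c(C(=O)Nc3ccc(Oc4ccnc5c4ccn5C)cc3)cc3cccnc32)cc1` gives 3460 nM, the higher of the two numbers, beyond the usual scatter from compound 1. Compound 3 `Cn1ccc2c(Oc3ccc(NC(=O)c4cc5cccnc5n(-c5ccc(Br)cc5F)c4=O)cc3)ccnc21` is not yet measured; it differs from compound 2 by 4-bromo-2-fluorophenyl in place of 4-methoxyphenyl on an aromatic nitrogen. Since compound 1 also carries the 4-bromo-2-fluorophenyl group and shows the lower number, a modest move toward stronger inhibition is expected, though compound 1 and compound 2 differ in a second place as well, so the step from compound 2 to compound 3 is expected to be about a 1.9-fold lower number from compound 2 to compound 3 (0.28 log units; within the scatter). Compound 3 is estimated at 1800 nM, with a likely range from 700 nM to 4500 nM.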

Compound 3, half-maximal inhibitory concentration: 1630 nM
For compound 3 the middle estimate is 1.1-fold (0.04 log units) above the measured one; measured number inside the range.
By their numbers in this assay, from the lowest: compounds 1 and 3 (each within the scatter of the next); then compound 2.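

In this assay, within the data shown here, the change from 4-methoxyphenyl to 4-bromo-2-fluorophenyl on an aromatic nitrogen gives a 2.1-fold lower number from compound 2 to compound 3 (0.33 log units; beyond the scatter) and is the first comparison of this position that differs in one place only. Methyl in place of hydrogen on an aromatic nitrogen gives a 1.0-fold higher number from compound 1 to compound 3 (0.02 log units; within the scatter) and so leaves the number within the scatter. No measurement shown here explains either step.
Whether the bromine or the fluorine accounts for the first step stays open, since the two groups differ in several atoms at once. On these data alone, how an unsubstituted phenyl or a chain ending in an amine would behave at this position also stays open.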